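Working notes: one pending analogue in a cytotoxicity series

The source may report more compounds than this note shows. Statements on the series, on what has been measured and on what is new or still open speak of the compounds shown alone.

Measured in a functional assay on A549 cells (Homo sapiens) for cytotoxicity, read by MTT assay, with a stated time of 24 h; a higher number here means a weaker inhibitor, a lower number a stronger inhibitor:
Compound 1, `FC(F)(F)C(F)(F)C(F)(F)C(F)(F)C(F)(F)C(F)(F)CCn1cc(COc2ccccc2-c2nc3ccccc3s2)nn1`, gives 15100 nM.
Compound 2, `FC(F)(F)Oc1ccc(-c2cc(COc3ccccc3-c3nc4ccccc4s3)on2)cc1`, gives 23900 nM.
Compound 3, `Fc1ccc(-n2cc(COc3ccccc3-c3nc4ccccc4s3)nn2)cc1`, gives 23300 nM.

Compound 2 stands among these three numbers without being set apart: its gap to compound 3 and its gap to compound 1 both lie within the usual scatter, so the three compounds cannot be ordered on this evidence.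

Compound 4, `Cc1ccc(-c2cc(COc3ccccc3-c3nc4ccccc4s3)on2)cc1`, is not yet measured in this assay. It differs from compound 2 in one place: methyl in place of trifluoromethoxy on an aromatic carbon. Among the compounds with values here, no pair of measured compounds differs in exactly this way, so the size of the step cannot be read off and is only expected. Since compound 1, compound 2 and compound 3 carry different outer groups yet fall together in this assay, for compound 4 the step is expected to be a 1.1-fold lower number from compound 2 to compound 4 (0.06 log units; within the scatter), in no direction beyond the scatter. Compound 4 is therefore estimated at 21000 nM, with a range from 8000 nM to 55000 nM.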

Compound 4, half-maximal inhibitory concentration: 16400 nM
The estimate for compound 4 lay 1.3-fold (0.11 log units) above the measured number; the measured number falls inside the stated range.
By their numbers in this assay, from the lowest: compounds 1, 4, 3 and 2 (each within the scatter of the next).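

In this assay, within the data shown here, methyl in place of trifluoromethoxy on an aromatic carbon, para to a large group, gives a 1.5-fold lower number from compound 2 to compound 4 (0.16 log units; within the scatter), the first step that can be read across a single place. A group of 5 heavy atoms, including 3 fluorine, and a group of 1 carbon therefore leave compound 2 and compound 4 indistinguishable at this position, so this change does not separate the pair. No measured information at hand accounts for this result.

As far as these compounds go, whether an amine or a carboxylic acid at this position would give a step beyond the scatter remains open. Also open, from the compounds shown here alone, is whether methyl in place of trifluoromethoxy would give a comparable step on a different core.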